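The compounds below may be only part of what the source reports. "The series", "measured", "known", "first", "only" and "open" are said of these compounds alone.

Measured so far in a functional assay on HCT-15 cells (Homo sapiens) for antiproliferative activity, read by sulforhodamine B assay; on this read-out lower numbers stand for stronger inhibition of growth and higher numbers for weaker inhibition of growth:

Compound 1 `CC1(C)CC(=O)c2s/c(=N/C3CCCCC3)oc2C1` — 12200 nM
Compound 2 `CC1(C)CC(=O)c2s/c(=N/c3ccc(Cl)cc3)oc2C1` — 3790 nM
Compound 3 `CC1CC(=O)c2s/c(=N/c3ccc(Cl)cc3)oc2C1` — 12200 nM

Compound 2 gives the lowest of the three numbers in this assay. Going by the values given here, compound 1, which carries a saturated six-membered ring in place of the chlorophenyl group, gives 12200 nM, and compound 3, which lacks one methyl on the saturated ring, gives 12200 nM; the only single-point step recorded is a 3.2-fold higher number from compound 2 to compound 3 (0.51 log units; beyond the scatter).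

Compound 4 `CC1(C)CC(=O)c2s/c(=N/c3ccc(F)cc3)oc2C1` differs from compound 2 in one place: fluoro in place of chloro on an aromatic carbon. Among the compounds with values here, no measured step touches the halogen on the aromatic ring; the one recorded step concerns a methyl on the saturated ring, so it says nothing direct about this change. With no guide from the data, the expectation is a step no larger than the scatter, if anything toward a slightly higher number. Compound 4 is therefore estimated at 5500 nM, within 2000 nM to 15000 nM, a change of a 1.5-fold higher number from compound 2 to compound 4 (0.16 log units; within the scatter) that is expected rather than known.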

Compound 4, concentration for 50% growth inhibition: 2390 nM
For compound 4 the middle estimate is 2.3-fold (0.36 log units) above the measured one; measured number inside the range.
By their numbers in this assay, from the lowest: compounds 4 and 2 (each within the scatter of the next); then compounds 1 and 3 (each within the scatter of the next).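

In this assay, putting fluoro in place of chloro on this aromatic carbon, para to a large group, gives a 1.6-fold lower number from compound 2 to compound 4 (0.20 log units; within the scatter), so the two compounds cannot be told apart on this read-out. Going by these compounds alone, this is the first view of a change at this position, and swapping one of these halogens for the other leaves the number within the scatter, unlike the step on the saturated ring, a 3.2-fold higher number from compound 2 to compound 3 (0.51 log units; beyond the scatter). No measurement shown here offers an explanation for how closely the two halogens agree.

Chloro and fluoro are each a single heavy atom, so it remains open how a methoxy group, an amine or a carboxylic acid would read on this same carbon. Also open, as far as these compounds go, is whether removing one methyl from the saturated ring would give a similar step when fluoro is present.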